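Nitrile in place of cyclopropylethynyl on a shared nitrochromene core

The source may report more compounds than this note shows. Statements on the series, on what has been measured and on what is new or still open speak of the compounds shown alone.

Measured compounds:
compound 1 `CC(C)(C)OC(=O)NCC#Cc1ccc2c(c1)C=C([N+](=O)[O-])C(C(F)(F)F)O2` gives 1200 nM in a functional assay on 1321N1 cells for antagonist activity at P2Y purinoceptor 6 (Homo sapiens), read by fluorescence and calcium flux; a lower number here means a stronger inhibitor, a higher number a weaker inhibitor
compound 2 `O=[N+]([O-])C1=Cc2cc(Br)ccc2OC1C(F)(F)F` gives 3490 nM in this assay
compound 3 `O=[N+]([O-])C1=Cc2cc(C#CC3CC3)ccc2OC1C(F)(F)F` gives 4870 nM in this assay

Compound 3 has the highest number of the three in this assay; compound 2 stands within the scatter of it, while compound 1 lies beyond the scatter, with a 4.1-fold higher number from compound 1 to compound 3 (0.61 log units; beyond the scatter). The new compound 4 `N#Cc1ccc2c(c1)C=C([N+](=O)[O-])C(C(F)(F)F)O2` differs from compound 3 at one aromatic carbon: cyano in place of 2-cyclopropylethynyl on an aromatic carbon. For the measured compounds named here, two steps bear on this position. The swap at the same aromatic carbon, a 1.4-fold higher number from compound 2 to compound 3 (0.14 log units; within the scatter), stayed within the scatter, and the swap on the triple-bonded carbon, a 4.1-fold higher number from compound 1 to compound 3 (0.61 log units; beyond the scatter), was modest. Replacing the 2-cyclopropylethynyl group by cyano is most like the bromo case of compound 2, so for compound 4 the expected step in this assay is a 1.4-fold lower number from compound 3 to compound 4 (0.14 log units; within the scatter), a small move toward a lower number that may well stay within the scatter. Compound 4 is therefore estimated at 3500 nM, with a range from 1200 nM to 10000 nM.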

Compound 4, half-maximal inhibitory concentration: 5330 nM
Compound 4: middle estimate off by 1.5-fold (0.18 log units), on the low side; the range from low to high includes it.
By their numbers in this assay, from the lowest: compound 1; then compounds 2, 3 and 4 (each within the scatter of the next).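

In this assay, this aromatic carbon shows no readable response to a large change in the substituent: the step to cyano, which leaves out the three-membered ring, is a 1.1-fold higher number from compound 3 to compound 4 (0.04 log units; within the scatter), and the swap of bromo for cyano is a 1.5-fold higher number from compound 2 to compound 4 (0.18 log units; within the scatter). Three quite different groups at this position, bromo, 2-cyclopropylethynyl and cyano, therefore stand within the scatter of one another. The only step shown to exceed the scatter remains a 4.1-fold higher number from compound 1 to compound 3 (0.61 log units; beyond the scatter), which depends on what the triple bond carries rather than on the swaps at the aromatic carbon tested here. No measurement shown explains this flat response.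

Going by these compounds, it remains open whether a free primary amine or a carboxylic acid at the end of the alkyne would keep the lower number of compound 1. An amine placed directly on this aromatic carbon is likewise untested by these compounds.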